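Swapping methyl for trifluoromethoxy: an expected step

This account rests on a few compounds, and the source may have more. Where it says the series, first, only, none or still open, it means among the compounds named here.

compound 1 `Cc1cc(NC(=O)Nc2ccc(C)c(Cl)c2)c2ccccc2n1`: 300 nM
compound 2 `Cc1ccc(NC(=O)Nc2cc(C)nc3ccccc23)cc1`: 1300 nM
compound 3 `Cc1cc(NC(=O)Nc2cccc(F)c2)c2ccccc2n1`: 100 nM

These three values come from a physicochemical assay for solubility, at pH 7.4 (on this read-out lower numbers stand for lower solubility and higher numbers for higher solubility), and compound 2 stands highest of the three. Compound 4 `Cc1cc(NC(=O)Nc2ccc(OC(F)(F)F)cc2)c2ccccc2n1` has not yet been measured. It differs from compound 2 by trifluoromethoxy in place of methyl on an aromatic carbon, para to a large group (trifluoromethoxy in place of methyl on an aromatic carbon).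

For the measured compounds named here, two measured steps bear on this, though neither makes the same swap. Hydrogen in place of chloro gives a 4.3-fold higher number from compound 1 to compound 2 (0.64 log units; beyond the scatter), a modest step. 3-fluorophenyl in place of 4-methylphenyl gives a 13-fold lower number from compound 2 to compound 3 (1.11 log units; beyond the scatter), a large one. With compound 1 at 300 nM and compound 3 at 100 nM, both altered on the same ring and both lower than compound 2, a step down in this assay is expected, of a size within that span. The expected step is a 6.5-fold lower number from compound 2 to compound 4 (0.81 log units; beyond the scatter). For compound 4 the estimated value is 200 nM, with an expected range from 50 nM to 700 nM.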

Compound 4, solubility: 300 nM
For compound 4 the middle estimate is 1.5-fold (0.18 log units) below the measured one; low and high end bracket the measured number.
By their numbers in this assay, from the lowest: compound 3; then compounds 1 and 4 (each within the scatter of the next); then compound 2.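

In this assay, for the compounds shown here, trifluoromethoxy in place of methyl gives a drop (a 4.3-fold lower number from compound 2 to compound 4 (0.64 log units; beyond the scatter)), and this is the first step here that changes only the group on this aromatic carbon, para to a large group. The earlier steps shown here touched this ring in other ways: one added a chloro, and the other exchanged the whole 4-methylphenyl. This single exchange shows that the number responds to the group at this place alone, with a change beyond the scatter, but no measurement at hand says why.

Only one replacement for the methyl is shown, so a single step cannot show a trend at this place. From the compounds shown here alone, whether an amine or a carboxylic acid on this carbon would keep the number of compound 2 or lower it remains open.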